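The source may hold more compounds than are shown below. What is called first, only, known or untested is meant among the compounds shown, and "the series" means these compounds.

Measured compounds:
- Compound 1 `COc1ccccc1-c1nnc(-c2ccc(C(=O)N/N=C/c3cc(O)ccc3O)cc2)o1`: 100000 nM
- Compound 2 `COc1ccccc1-c1nnc(-c2ccc(C(=O)N/N=C/c3ccccc3O)cc2)o1`: 207000 nM
- Compound 3 `COc1ccccc1-c1nnc(-c2ccc(C(=O)N/N=C/c3ccc(Cl)cc3Cl)cc2)o1`: 78800 nM

In an ADME assay on THP-1 cells (Homo sapiens) for cytotoxicity (on this read-out lower numbers stand for stronger inhibition and higher numbers for weaker inhibition), compound 2 gives 207000 nM, the highest of the three numbers and therefore the weakest cytotoxicity seen. Its two neighbours sit below it: the step of a 2.1-fold higher number from compound 1 to compound 2 (0.32 log units; beyond the scatter) and the step of a 2.6-fold lower number from compound 2 to compound 3 (0.42 log units; beyond the scatter) are both modest and both beyond the scatter. Compound 4 `COc1ccccc1-c1nnc(-c2ccc(C(=O)N/N=C/c3ccc(O)cc3)cc2)o1` has not yet been measured. It shares the core of compound 2 and differs only in the hydroxyphenyl ring: 4-hydroxyphenyl in place of 2-hydroxyphenyl on a carbon with a double bond to nitrogen.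

Among the measured compounds shown here, no measured step moves the hydroxy from one position to another on that ring; the measured steps remove a hydroxy or replace the whole ring. The removal step a 2.1-fold higher number from compound 1 to compound 2 (0.32 log units; beyond the scatter) and the replacement step a 2.6-fold lower number from compound 2 to compound 3 (0.42 log units; beyond the scatter) are both small, so the whole series spans little more than the scatter. The change to compound 4 keeps the same atoms and the same donor and acceptor, so the expected step in this assay is none beyond the scatter, with no clear direction. The expected step is a 1.4-fold lower number from compound 2 to compound 4 (0.14 log units; within the scatter). For compound 4 the estimated value is 150000 nM, with a range from 70000 nM to 320000 nM.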

Compound 4, half-maximal inhibitory concentration: 261000 nM
The estimate for compound 4 lay 1.7-fold (0.24 log units) below the measured number, within the range that was stated.
By their numbers in this assay, from the lowest: compounds 3 and 1 (each within the scatter of the next); then compounds 2 and 4 (each within the scatter of the next).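

In this assay, among the compounds shown here, 4-hydroxyphenyl in place of 2-hydroxyphenyl on a carbon with a double bond to nitrogen gives a step that stays within the scatter (a 1.3-fold higher number from compound 2 to compound 4 (0.10 log units; within the scatter)), so this is the first direct look at relocating the hydroxy on this ring, and relocating it leaves the read-out unresolved from where it was. The new compound also sides with compound 2 against the other two ring types, with both steps modest but beyond the scatter (a 3.3-fold higher number from compound 3 to compound 4 (0.52 log units; beyond the scatter); a 2.6-fold higher number from compound 1 to compound 4 (0.42 log units; beyond the scatter)), so the two compounds carrying a single hydroxy on this ring both give higher numbers than the 2,5-dihydroxyphenyl and 2,4-dichlorophenyl compounds, and no compound shown goes against this. Nothing at hand offers a reason for these differences.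

From the compounds shown here alone, whether an amine or a carboxylic acid in place of the hydroxy on this ring would shift the number in this assay stays open. Also open is what a longer chain between this ring and the carbon with a double bond to nitrogen would do, since every compound shown keeps the ring directly on that carbon and keeps the shared core unchanged.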